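The source may report more compounds than this note shows. Statements on the series, on what has been measured and on what is new or still open speak of the compounds shown alone.

The measured compounds and their values:

compound 1, `Cc1nc(N)c2c(-c3cccs3)cn([C@@H]3O[C@H](CO)[C@@H](O)[C@H]3O)c2n1`, > 20000 nM
compound 2, `Cc1nc(N)c2c(-c3ccco3)cn([C@@H]3O[C@H](CO)[C@@H](O)[C@H]3O)c2n1`, > 20000 nM
compound 3, `Nc1nc2c(c(-c3ccco3)cn2[C@@H]2O[C@H](CO)[C@@H](O)[C@H]2O)c(=O)[nH]1`, > 20000 nM

All three were tested in a functional assay on K562 cells (Homo sapiens), read by MTT assay, with a stated time of 72 h; on this read-out lower numbers stand for stronger inhibition and higher numbers for weaker inhibition. In this assay compound 1 gives > 20000 nM, which is a limit of the assay and not a number. Compound 2 likewise gives > 20000 nM, also a limit. Compound 3 gives > 20000 nM, again a limit. Compounds 1 and 2 share a core and differ by thiophen-2-yl in place of furan-2-yl on an aromatic carbon. The step between them is a step that the two limits leave unreadable from compound 2 to compound 1. The difference between the core of compound 3 and the core of compound 2 is not broken down here.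

Compound 4, `Nc1nc2c(c(-c3cccs3)cn2[C@@H]2O[C@H](CO)[C@@H](O)[C@H]2O)c(=O)[nH]1`, has not yet been measured in this assay. It relates to compound 3 by thiophen-2-yl in place of furan-2-yl on an aromatic carbon, the same change that separates compound 2 from compound 1.

Against this, the step is expected to be a step that the limit leaves unreadable from compound 3 to compound 4, set beside a step that the two limits leave unreadable from compound 2 to compound 1. The expectation rests on (the limit of > 20000 nM in this assay, at which 3 of the 3 values shown sit), so the same change is not expected to bring compound 4 inside the measurable range. Compound 4 is therefore estimated at 30000 nM, with an expected spread from 12000 nM to 120000 nM. The likeliest outcome for compound 4 is that this assay again reports only a limit.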

Compound 4, half-maximal inhibitory concentration: > 20000 nM
Compound 4 was reported as a limit (the forecaster's own chance of this, stated with the estimate: 85%); the middle value does not contradict the limit.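

In this assay compound 4 gives > 20000 nM, which is a limit of the assay and not a number. Compound 3 also stands at a limit, so no step can be read between compound 3 and compound 4 for thiophen-2-yl in place of furan-2-yl. The compounds shown leave open how any of them would compare inside the measurable range, as every value is a limit: the limit of > 20000 nM in this assay, at which 4 of the 4 values shown sit.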